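The source may report more compounds than this note shows. Statements on the series, on what has been measured and on what is new or still open speak of the compounds shown alone.

In a functional assay on HOS cells (Homo sapiens) for inhibition, read by CCK-8 assay, with a stated time of 72 h, tested at 1 uM (a higher number here means more inhibition at the concentration tested (going by the name of the read-out), a lower number less inhibition), the measured compounds are:

compound 1 `COc1ccc(C)cc1N1C(=O)CSC1c1cccc(C(=O)NCCCCc2ccccc2)c1`: 42%
compound 2 `O=C(NCCCCc1ccccc1)c1cccc(C2SCC(=O)N2c2ccccc2)c1`: 55%
compound 3 `CCN1C(=O)CSC1c1cccc(C(=O)NCCCCc2ccccc2)c1`: 6%

Compound 3 stands lowest of the three in this assay, separated from both other compounds by more than the scatter. Compound 4 `COc1ccc(N2C(=O)CSC2c2cccc(C(=O)NCCCCc3ccccc3)c2)c(OC)c1` has not yet been measured; it differs from compound 3 by 2,4-dimethoxyphenyl in place of ethyl on an amide-type nitrogen in a ring. Within the data shown here, two measured steps bear on this change: a number 36 percentage points lower from compound 1 to compound 3 (beyond the scatter) and a number 49 percentage points lower from compound 2 to compound 3 (beyond the scatter), both large and both putting ethyl on the ring nitrogen in place of a group of the kind now entering. Compound 4 is therefore expected to show a large upward step in this assay, namely a number 39 percentage points higher from compound 3 to compound 4 (beyond the scatter). Compound 4 is estimated at 45% in this assay, with a range from 22% to 65%.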

Compound 4, a percentage reported as inhibition, at one concentration (the size of the read-out at that concentration, not a potency): 82%
Compound 4: middle estimate off by 37 percentage points, on the low side; measured number above the stated range.
By their numbers in this assay, from the lowest: compound 3; then compound 1; then compound 2; then compound 4.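

In this assay, the step of a number 76 percentage points higher from compound 3 to compound 4 (beyond the scatter) is large, but the new information is that aryl groups at this amide-type nitrogen also differ among themselves: a number 27 percentage points higher from compound 2 to compound 4 (beyond the scatter) and a number 40 percentage points higher from compound 1 to compound 4 (beyond the scatter) are both beyond the scatter. Adding substituents to the phenyl therefore does not shift the number in a single direction, since compound 1 stands below compound 2 and compound 4 stands above it. Nothing available here explains this difference.

On these data alone, it remains open whether one methoxy group alone, as in 4-methoxyphenyl or 2-methoxyphenyl, would give the same gain. As far as these compounds go, it is also open how an amine or a carboxylic acid on that phenyl would read.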